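The source may hold more compounds than are shown below. What is called first, only, known or untested is meant among the compounds shown, and "the series" means these compounds.

Compound 1 `CCCN1CCC(C(=O)Nc2cc(Cl)c(N)cc2OC)CC1` and compound 2 `COc1cc(N)c(Cl)cc1NC(=O)C1CCN(CC2CCCC2)CC1` share one core and differ at a single place. In a functional assay on the whole organism for antagonist activity, with Mus musculus as the target (a lower number here means that less compound is needed, a higher number that more compound is needed for the effect), compound 1 reaches only a limit, > 10 mg/kg. In this assay compound 2 likewise reaches only a limit, > 10 mg/kg. The step that the two limits leave unreadable from compound 1 to compound 2 therefore cannot be read, since both ends are limits. Compound 2 thus stands at the limit of this assay, as the limit of > 10 mg/kg in this assay, at which 2 of the 2 values shown sit, records for both values shown.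

Compound 3 `COc1cccc(CN2CCC(C(=O)Nc3cc(Cl)c(N)cc3OC)CC2)c1` differs from compound 2 by 3-methoxyphenyl in place of cyclopentyl on a saturated chain carbon bound to an amine nitrogen in a ring. Within the data shown here, no measured step bears directly on this change, and the only step at hand, a step that the two limits leave unreadable from compound 1 to compound 2, gives no size. With both measured values sitting at the limit of > 10 mg/kg in this assay, at which 2 of the 2 values shown sit, no direction can be taken from the data, and compound 3 is expected to remain near that limit. The step of a number no higher from compound 2 to compound 3 (the limit leaves the size open) is estimated as small. Compound 3 is therefore estimated at 10 mg/kg, with a range from 3 mg/kg to 30 mg/kg.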

Compound 3, dose for half-maximal effect: > 4 mg/kg
Compound 3: a limit, no number (the forecaster's own chance of this, stated with the estimate: 70%); the middle value lies beyond the limit too.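

In this assay, among these compounds, compound 3 also reaches only a limit, > 4 mg/kg, so no step among compound 1, compound 2 and compound 3 can be read. The compounds shown leave open whether ethyl, cyclopentyl or 3-methoxyphenyl at this place changes the dose needed at all.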